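The compounds below may be only part of what the source reports. "The series", "measured", "known", "first", "only" and "open" are said of these compounds alone.

In an assay on HEK293 cells for displacement of a labelled ligand from metabotropic glutamate receptor 5 (Homo sapiens), with a stated time of 2 h (on this read-out lower numbers stand for stronger inhibition and higher numbers for weaker inhibition), compound 1 `CC(C)N1CCc2nc(C#Cc3ccccc3Cl)ccc2C1=O` gives 5680 nM. Compound 2 `CC(C)N1CCc2nc(C#Cc3cccc(Cl)c3)ccc2C1=O` gives 100 nM in this assay, and the step of a 57-fold lower number from compound 1 to compound 2 (1.75 log units; beyond the scatter) goes with the change (3-chlorophenyl in place of 2-chlorophenyl on a triple-bonded carbon). Compound 3 `O=C1c2ccc(C#Cc3ccccc3Cl)nc2CCN1C1CCCC1` differs from compound 1 by cyclopentyl in place of isopropyl on an amide-type nitrogen in a ring. For compound 3 this assay reports only a limit, > 32000 nM. The step of an at least 5.6-fold higher number from compound 1 to compound 3 (0.75 log units; beyond the scatter) therefore rests on that limit (the limit of > 32000 nM in this assay, at which 1 of the 3 values shown sits). Compound 4 `O=C1c2ccc(C#Cc3cccc(Cl)c3)nc2CCN1C1CCCC1` is not yet measured; it differs from compound 3 by 3-chlorophenyl in place of 2-chlorophenyl on a triple-bonded carbon, the same change as from compound 1 to compound 2, made on the core of compound 3 rather than that of compound 1. Given the step of a 57-fold lower number from compound 1 to compound 2 (1.75 log units; beyond the scatter), a lowering of comparable size is expected, so the expected step is an at least 16-fold lower number from compound 3 to compound 4 (1.20 log units; beyond the scatter), starting from a limit rather than a number. Compound 4 is thus expected to give about 2000 nM in this assay, estimated to lie between 500 nM and 15000 nM.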

Compound 4, inhibition constant: 5230 nM
Compound 4: middle estimate off by 2.6-fold (0.42 log units), on the low side, and the stated range covers the measured number.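

In this assay both changes carry over in direction: 3-chlorophenyl in place of 2-chlorophenyl gives an at least 6.1-fold lower number from compound 3 to compound 4 (0.78 log units; beyond the scatter) on the core of compound 3, and cyclopentyl in place of isopropyl gives a 52-fold higher number from compound 2 to compound 4 (1.72 log units; beyond the scatter) on the core of compound 2. Compound 3 gives > 32000 nM, which is a limit and not a number. The direction of the chlorophenyl change therefore holds on both cores, but its size is not shown to carry over: the same change on two cores in this assay, a 57-fold lower number (1.75 log units; beyond the scatter) from compound 1 to compound 2 and an at least 6.1-fold lower number (0.78 log units; beyond the scatter) from compound 3 to compound 4; the limit leaves it open whether they differ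

Open, going by these compounds, is whether the two effects hold for other groups on the amide-type nitrogen in a ring, such as cyclohexyl or a longer chain like n-butyl. Also open, on these data alone, is how plain phenyl on the triple-bonded carbon compares with the two chlorophenyl groups.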